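This account rests on a few compounds, and the source may have more. Where it says the series, first, only, none or still open, it means among the compounds named here.

Measured in a physicochemical assay for pharmacokinetics; a higher number here means that the compound lasts longer, a lower number that the compound disappears faster:
- compound 1 `O=C(NCc1cccc2ccccc12)N1C(=O)c2ccccc2S1(=O)=O`: 0.395 h
- compound 2 `COc1cccc(CNC(=O)N2C(=O)c3ccccc3S2(=O)=O)c1`: 0.523 h

With only these two measurements, compound 2 at 0.523 h lies within the usual scatter of compound 1 at 0.395 h. Repeated measurements of a single compound spread about as widely, so the two cannot be ranked.

The next compound, compound 3 `O=C(NCc1cccs1)N1C(=O)c2ccccc2S1(=O)=O`, has not yet been measured. It keeps the shared core of compound 2 but carries thiophen-2-yl in place of 3-methoxyphenyl on a saturated chain carbon bound to an amide-type nitrogen.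

For the measured compounds named here, no two measured compounds differ in just one place, so no measured step shows directly how large such a change might be. Going by the values given here, the only guide is how close the two known values are in this assay, and that gives no firm direction. A change beyond the scatter is therefore not expected. The expected step is a 1.2-fold lower number from compound 2 to compound 3 (0.07 log units; within the scatter). For compound 3 the estimated half-life is 0.45 h, with an expected range from 0.2 h to 1 h.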

Compound 3, half-life: 0.365 h
Estimate against measurement, compound 3: 1.2-fold (0.09 log units) above, within the range that was stated.
By their numbers in this assay, from the lowest: compounds 3, 1 and 2 (each within the scatter of the next).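

Replacing 3-methoxyphenyl with thiophen-2-yl on a saturated chain carbon bound to an amide-type nitrogen gives the only step shown that alters a single place, and in this assay it reads as a 1.4-fold lower number from compound 2 to compound 3 (0.16 log units; within the scatter). At this position, then, a six-membered aromatic ring of carbon only can be exchanged for a five-membered aromatic ring with 1 hetero atom, with 8 heavy atoms leaving and 5 entering, and the result cannot be told apart from repeat-measurement noise. No measured evidence here speaks to what lies behind this reading.

All the groups shown at this place are aromatic rings, so it remains open whether an amine, a carboxylic acid or a longer chain of saturated carbons there would also stay within the scatter in this assay. Every compound shown also keeps the shared core, so a single step cannot tell whether the same exchange would read alike on a different core.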